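The source may report more compounds than this note shows. Statements on the series, on what has been measured and on what is new or still open speak of the compounds shown alone.

Measured compounds in the series:

Compound 1 `CCC1(Cc2ccccc2)OS(=O)(=O)C=C1OCc1ccc(Cl)cc1`. In an ADME assay on HEL cells (Homo sapiens) for cytotoxicity, with a stated time of 3 days (a lower number here means that less compound is tolerated, a higher number that more compound is tolerated), compound 1 gives >= 50000 nM, which is a limit of the assay.
Compound 2 `CCC1(Cc2ccccc2)OS(=O)(=O)C=C1OCc1ccc(F)cc1`. In this assay compound 2 gives >= 50000 nM, also a limit of the assay.
Compound 3 `CCC1(Cc2ccccc2)OS(=O)(=O)C=C1OCc1ccc(Br)cc1`. In this assay compound 3 gives 80000 nM.

Among the compounds with values here, compound 3 thus carries the only actual number in this assay; the other two values are limits. The three measured steps, a step that the two limits leave unreadable from compound 1 to compound 2, a step that the limit leaves unreadable from compound 1 to compound 3 and a step that the limit leaves unreadable from compound 2 to compound 3, are all unreadable, since the limit of >= 50000 nM in this assay, at which 2 of the 3 values shown sit, covers two of the three compounds. The halogen exchanges therefore give no readable size of step at all.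

Compound 4 `CCC1(Cc2ccccc2)OS(=O)(=O)C=C1OCc1ccc(C(C)(C)C)cc1` differs from compound 3 by tert-butyl in place of bromo on an aromatic carbon. Within the data shown here, no measured step bears directly on this exchange; the halogen steps only show that none of the three compounds moved to a readable number in this assay, so the expectation for a 1.3-fold lower number from compound 3 to compound 4 (0.12 log units; within the scatter) is no step beyond the scatter. Compound 4 is therefore estimated at 60000 nM, within 30000 nM to 120000 nM, with a fair chance that only a limit is reported.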

Compound 4, minimum cytotoxic concentration: >= 400000 nM
Compound 4: only a limit was reported (the forecaster's own chance of this, stated with the estimate: 60%); middle value at least 6.6-fold (0.82 log units) from the limit.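

In this assay, the place on the aromatic ring, para to a large group, now gives a first readable step: tert-butyl in place of bromo gives an at least 5.0-fold higher number from compound 3 to compound 4 (0.69 log units; beyond the scatter), whereas the halogen exchanges gave no readable size. The value of compound 4 is itself a limit of the assay, so this step has a lower bound and no full size: the limit of >= 400000 nM in this assay, at which 1 of the 4 values shown sits. The steps to compound 4 from compound 1 and from compound 2 cannot be read: the limit of >= 50000 nM in this assay, at which 2 of the 4 values shown sit.

Going by these compounds, the true distance between compound 3 and compound 4 remains open, as does whether the step belongs to tert-butyl in particular or extends to smaller carbon groups such as methyl. A carboxylic acid or an amine in the same place would test whether the step carries over to groups with hydrogen-bond donors or acceptors.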